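Replacing chloro with (pyridin-2-yl)methoxy: cytotoxicity notes

The source may report more compounds than this note shows. Statements on the series, on what has been measured and on what is new or still open speak of the compounds shown alone.

The series is read in an ADME assay on HEK293 cells (Homo sapiens) for cytotoxicity, with a stated time of 6 h; a higher number here means that more compound is tolerated, a lower number that less compound is tolerated. Compound 1 (`CCCCNc1nc(N)nc2cc(C(=O)N(C)C)ccc12`) is reported as > 18000 nM, which is a limit and not a number. Compound 2 (`CCCCNc1nc(N)nc2ccc(CCc3ccccn3)cc12`) is reported as > 18000 nM, again a limit. Among the compounds with values here, compound 3 (`CCCCNc1nc(N)nc2cccc(Cl)c12`) gives 100 nM, the only true number in the set so far.

The next step leads to compound 4 (`CCCCNc1nc(N)nc2cccc(OCc3ccccn3)c12`), with (pyridin-2-yl)methoxy in place of chloro on an aromatic carbon. Within the data shown here, no measured pair in the set differs in one place, so the size of this step has no direct precedent. Among the measured compounds shown here, compound 3, the only compound carrying chloro, gives 100 nM. Compounds 1 and 2, which lack it, both stand at the limit. On that thin basis, with three compounds only, a move towards more compound being tolerated is expected once chloro leaves. The step of a 40-fold higher number from compound 3 to compound 4 (1.60 log units; beyond the scatter) is expected to lie well beyond the scatter, although its size is uncertain. For compound 4 the estimated value is 4000 nM, with an expected range of 300 nM to 18000 nM.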

Compound 4, half-maximal cytotoxic concentration: > 25000 nM
Compound 4 ended at the assay's limit; the forecaster's own chance of this, stated with the estimate: 40%; at least 6.2-fold (0.79 log units) between middle value and limit.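

In this assay, within the data shown here, (pyridin-2-yl)methoxy in place of chloro on an aromatic carbon gives an at least 250-fold higher number from compound 3 to compound 4 (2.39 log units; beyond the scatter), the first change that can be read at a single place. With the rest of the structure unchanged, the low value of compound 3 is therefore not set by the shared core alone: it depends on what sits at this aromatic carbon, and this carbon can carry a much larger group, with an added aromatic ring, without less compound being tolerated. The full size of the step remains unknown, since the entry for compound 4 is a limit and not a number: the limit of > 25000 nM in this assay, at which 1 of the 4 values shown sits.

The compounds shown do not separate the loss of chloro from the arrival of (pyridin-2-yl)methoxy, and a small group such as methoxy, or an amine, at the same carbon would show how much of the step each accounts for. On these data alone, whether the pyridine nitrogen matters also stays open, as a benzyloxy group in the same place would be needed to tell.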